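The source may hold more compounds than are shown below. What is called first, only, known or untested is meant among the compounds shown, and "the series" means these compounds.

Measured in a functional assay on A549 cells (Homo sapiens) for cytotoxicity, read by colorimetric assay and MTT assay; on this read-out lower numbers stand for stronger inhibition and higher numbers for weaker inhibition:
- Compound 1 `COc1cc(OC)c2cc(-c3ccccc3)c(O)nc2c1`: 10000 nM
- Compound 2 `COc1cc(OC)c2cc(-c3ccc(OCc4ccccc4)cc3)c(O)nc2c1`: 10000 nM
- Compound 3 `COc1ccc(-c2cc3c(OC)cc(OC)cc3n(CCCC#N)c2=O)cc1`: 10000 nM

Compound 3 stands level with compound 1 and compound 2, so the three measured compounds show no spread in this assay. The next compound, compound 4 `COc1ccc(-c2cc3c(OC)cc(OC)cc3n(CCC(=O)OCc3ccccc3)c2=O)cc1`, keeps the core of compound 3 and changes its chain on the aromatic nitrogen: benzyloxycarbonyl in place of cyanomethyl on a saturated chain carbon, two bonds along the chain from an aromatic nitrogen. In short, benzyloxycarbonyl comes in place of cyanomethyl on a saturated chain carbon, two bonds along the chain from an aromatic nitrogen.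

Within the data shown here, only one measured step bears on this, and only loosely. Benzyloxy in place of hydrogen on an aromatic carbon gave no change at the digits printed from compound 1 to compound 2 (within the scatter), and that change lies on an aromatic carbon, not on this chain. Among the measured compounds shown here, no measured compound carries a change on the chain itself, so the evidence is thin, and no step beyond the scatter is expected, in either direction. The expected step is a 1.3-fold lower number from compound 3 to compound 4 (0.10 log units; within the scatter). For compound 4 the estimated value is 8000 nM, with an expected range of 3000 nM to 15000 nM.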

Compound 4, half-maximal inhibitory concentration: 10000 nM
Compound 4: the middle estimate sits 1.3-fold (0.10 log units) below what was measured; low and high end bracket the measured number.
By their numbers in this assay, from the lowest: compounds 1, 2, 3 and 4 (each within the scatter of the next).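

In this assay, among these compounds, the chain on the aromatic nitrogen now carries a measured change for the first time, and benzyloxycarbonyl in place of cyanomethyl gave no change at the digits printed from compound 3 to compound 4 (within the scatter). Among the compounds shown here, this swap is much larger than the one between compound 1 and compound 2: a six-membered aromatic ring enters, a triple bond leaves, and still the read-out does not separate the two compounds. No available evidence accounts for this flat result.

Going by these compounds, what remains open is whether an amine or a carboxylic acid in place of benzyloxycarbonyl, or a longer chain, would move the number on this chain. With all four compounds level, the compounds shown do not reveal which part of the structure, if any, this read-out responds to.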